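A few compounds are considered here, and "the series" means these few. Any claim that something is new, unique, unknown or untested is made for them only; others in the source may bear on it.

Within the data shown here, compound 2 `CC(C)n1cc(C(=O)Nc2ccc(-c3cn(C)c4ncnc(N)c34)cc2)c(=O)c(-c2ccc(F)cc2)c1` gives 0.4 nM in an assay on isolated protein for inhibition of tyrosine-protein kinase receptor UFO (Homo sapiens), read by ELISA (on this read-out higher numbers stand for weaker inhibition and lower numbers for stronger inhibition), and is the only number in the set. Compound 1 `COCCCn1cc(C(=O)Nc2ccc(-c3cn(C)c4ncnc(N)c34)cc2)c(=O)c(-c2ccc(F)cc2)c1` is reported in this assay only as a limit, > 10 nM. The step from compound 1 to compound 2, isopropyl in place of 3-methoxypropyl on an aromatic nitrogen, is an at least 25-fold lower number from compound 1 to compound 2 (1.39 log units; beyond the scatter); with one value sitting at the limit (the limit of > 10 nM in this assay, at which 1 of the 2 values shown sits), its true size is open. Compound 3 `Cn1cc(-c2ccc(NC(=O)c3cn(C4CCOCC4)cc(-c4ccc(F)cc4)c3=O)cc2)c2c(N)ncnc21` carries oxan-4-yl in place of isopropyl on an aromatic nitrogen. Among the measured compounds shown here, only that one step bears on this position, so an oxan-4-yl substituent is expected to cost little, a 2.0-fold higher number from compound 2 to compound 3 (0.30 log units; within the scatter). Compound 3 is therefore estimated at 0.8 nM, between 0.2 nM and 3 nM.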

Compound 3, half-maximal inhibitory concentration: 1.1 nM
Estimate against measurement, compound 3: 1.4-fold (0.14 log units) below; the measured number falls inside the stated range.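

In this assay, oxan-4-yl on the aromatic nitrogen keeps the number low, yet the change from isopropyl is a step beyond the scatter (a 2.8-fold higher number from compound 2 to compound 3 (0.44 log units; beyond the scatter)). An ether oxygen on this substituent therefore need not cost much, since the ring carrying one stays well ahead of the open 3-methoxypropyl chain (an at least 9.0-fold lower number from compound 1 to compound 3 (0.95 log units; beyond the scatter)). The value of compound 1 is a limit, so the true size of that step is open: the limit of > 10 nM in this assay, at which 1 of the 3 values shown sits.

Open, on these data alone, is whether cyclohexyl, a ring without the oxygen, would match isopropyl or oxan-4-yl. Also open, as far as these compounds go, is how a basic amine such as piperidin-4-yl would fare here.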